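From Nitro to Methoxy at the Assay Limit

A few compounds are considered here, and "the series" means these few. Any claim that something is new, unique, unknown or untested is made for them only; others in the source may bear on it.

Measured so far in a functional assay on BT-474 cells (Homo sapiens) for antiproliferative activity, read by MTT assay, with a stated time of 72 h; a higher number here means a weaker inhibitor, a lower number a stronger inhibitor
- compound 1 `Cn1cc(-c2cnc3ncnc(NCc4cccc([N+](=O)[O-])c4)c3c2)cn1` gives > 100000 nM (a limit)
- compound 2 `CC(Nc1ncnc2ncc(-c3cnn(C)c3)cc12)c1c(Cl)ccc(F)c1Cl` gives > 100000 nM (a limit)

Compound 1 stands at a limit and not at a number (> 100000 nM). The same is true of compound 2 (> 100000 nM). All the evidence so far therefore comes down to one observation (the limit of > 100000 nM in this assay, at which 2 of the 2 values shown sit).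

Compound 3 (`COc1cccc(CNc2ncnc3ncc(-c4cnn(C)c4)cc23)c1`) has yet to be tested. It differs from compound 1 in one place, with methoxy in place of nitro on an aromatic carbon, so 3-nitrophenyl becomes 3-methoxyphenyl. Going by the values given here, no two measured compounds differ in one place only, which leaves no measured step to size this change against. Compound 1 sits at a limit (> 100000 nM), so no step beyond the usual scatter is expected in this assay for this swap. The expected change is small (a number no higher from compound 1 to compound 3 (the limit leaves the size open)). For compound 3 the estimated value is 100000 nM with an expected range from 30000 nM to 150000 nM and a report as a limit alone is likely.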

Compound 3, half-maximal inhibitory concentration: > 100000 nM
Compound 3: only a limit was reported; the forecaster's own chance of this, stated with the estimate: 75%; the middle value lies on the limit itself.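

Compound 3 gives > 100000 nM, a limit and not a number. Compound 1 also stands at a limit, so no step can be read between compound 1 and compound 3. How far 3-nitrophenyl and 3-methoxyphenyl truly differ stays open, because every value shown is the same limit: the limit of > 100000 nM in this assay, at which 3 of the 3 values shown sit.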